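The source may hold more compounds than are shown below. What is called first, only, known or untested is meant among the compounds shown, and "the series" means these compounds.

In a functional assay on HCT-116 cells (Homo sapiens) for inhibition (a higher number here means a weaker inhibitor, a lower number a stronger inhibitor), compound 1 (`CCNCc1cc(-c2c(C(=O)NCC)noc2-c2cc(C(C)C)c(O)cc2O)on1`) gives 45 nM, and compound 2 (`CCNC(=O)c1noc(-c2cc(C(C)C)c(O)cc2O)c1-c1cc(C(=O)NC)no1`) gives 124 nM, the higher of the two numbers. Compound 3 (`CCNC(=O)c1noc(-c2cc(C(C)C)c(O)cc2O)c1-c1ccn(CC)n1`) differs from compound 2 by 1-ethyl-1H-pyrazol-3-yl in place of 3-(methylcarbamoyl)-1,2-oxazol-5-yl on an aromatic carbon, with 1-ethyl-1H-pyrazol-3-yl in place of 3-(methylcarbamoyl)-1,2-oxazol-5-yl on an aromatic carbon. Within the data shown here, the only measured step, a 2.8-fold higher number from compound 1 to compound 2 (0.44 log units; beyond the scatter), is modest and comes from methylcarbamoyl replacing (ethylamino)methyl, so the methylcarbamoyl group that leaves here is tied to the higher number. It gives only indirect guidance for a change of the whole group. A modest move to a lower number is expected, estimated as a 1.8-fold lower number from compound 2 to compound 3 (0.25 log units; within the scatter). Compound 3 is expected at 70 nM, with an estimated range of 20 nM to 250 nM.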

Compound 3, half-maximal inhibitory concentration: 25 nM
For compound 3 the middle estimate is 2.8-fold (0.45 log units) above the measured one, and the stated range covers the measured number.
By their numbers in this assay, from the lowest: compounds 3 and 1 (each within the scatter of the next); then compound 2.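

In this assay, 1-ethyl-1H-pyrazol-3-yl in place of 3-(methylcarbamoyl)-1,2-oxazol-5-yl gives a 5.0-fold lower number from compound 2 to compound 3 (0.70 log units; beyond the scatter) and shows that this position tolerates a group with neither the methylcarbamoyl group nor a hydrogen-bond donor. Against 3-((ethylamino)methyl)-1,2-oxazol-5-yl the same group gives a 1.8-fold lower number from compound 1 to compound 3 (0.26 log units; within the scatter) and so is not separated from it in this assay. No measured evidence accounts for either step.

The compounds shown leave open what the ethyl group on the pyrazole contributes. A methyl group or a longer chain there, or an amine on that ring, would address this.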